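This account rests on a few compounds, and the source may have more. Where it says the series, first, only, none or still open, it means among the compounds named here.

Of the compounds shown here, three built on the same core have been measured. Compound 1 `CC(C)NC(=O)c1ccc2cc(C(O)(c3c[nH]cn3)C(C)C)ccc2c1` gives 75 nM in an assay on isolated protein for inhibition of steroid 17-alpha-hydroxylase/17,20 lyase (Homo sapiens) (on this read-out higher numbers stand for weaker inhibition and lower numbers for stronger inhibition), the highest of the three numbers. Compound 2 `CCCNC(=O)c1ccc2cc(C(O)(c3c[nH]cn3)C(C)C)ccc2c1` gives 38 nM, and compound 3 `COC(=O)c1ccc2cc(C(O)(c3c[nH]cn3)C(C)C)ccc2c1` gives 24 nM. The step of a 2.0-fold lower number from compound 1 to compound 2 (0.30 log units; within the scatter) stays within the scatter, whereas the step of a 3.1-fold lower number from compound 1 to compound 3 (0.49 log units; beyond the scatter) is modest but beyond it. Compound 4 `CNC(=O)Nc1ccc2cc(C(O)(c3c[nH]cn3)C(C)C)ccc2c1` differs from compound 1 as follows: (methylcarbamoyl)amino in place of isopropylcarbamoyl on an aromatic carbon. Both measured steps from compound 1 alter the same substituent and both lower the number, so for compound 4 a small lowering in this assay is expected, or none beyond the scatter. Compound 4 is therefore estimated at 50 nM, with a range from 20 nM to 150 nM. The expected step is a 1.5-fold lower number from compound 1 to compound 4 (0.18 log units; within the scatter).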

Compound 4, half-maximal inhibitory concentration: 36 nM
Beside the measured number, compound 4's estimate is 1.4-fold (0.14 log units) above it, and the stated range covers the measured number.
By their numbers in this assay, from the lowest: compounds 3, 4, 2 and 1 (each within the scatter of the next, the first and the last beyond it).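

The earlier compounds shown here all carried their carbonyl directly on this aromatic carbon, whereas (methylcarbamoyl)amino attaches through a nitrogen and has two hydrogen-bond donors, yet the number still falls, with a 2.1-fold lower number from compound 1 to compound 4 (0.32 log units; beyond the scatter). Against the other two compounds the change stays inside the scatter, with a 1.5-fold higher number from compound 3 to compound 4 (0.18 log units; within the scatter) and a 1.1-fold lower number from compound 2 to compound 4 (0.02 log units; within the scatter). No measurement at hand accounts for these differences. As far as these compounds go, it remains open how a plain amine or a carboxylic acid on this aromatic carbon would read, and whether a longer chain in place of the methyl would shift the number.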